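Compound 3: 2-chlorophenyl replaces 4-(trifluoromethyl)phenyl

This account rests on a few compounds, and the source may have more. Where it says the series, first, only, none or still open, it means among the compounds named here.

Measured in an ADME assay on Caco-2 cells (Homo sapiens) for permeability, in the apical to basolateral direction, at pH 7.4; a lower number here means that the compound crosses the layer more slowly, a higher number that the compound crosses the layer faster:
Compound 1 `Cc1oc(-c2ccc(Cl)cc2)nc1C(=O)N[C@H]1CN(S(=O)(=O)c2ccccc2)C[C@@H]1C(=O)N[C@H]1CCCNC1`: 0.14 10^-6 cm/s
Compound 2 `Cc1oc(-c2ccc(C(F)(F)F)cc2)nc1C(=O)N[C@H]1CN(S(=O)(=O)c2ccccc2)C[C@@H]1C(=O)N[C@H]1CCCNC1`: 0.1 10^-6 cm/s

Within the data shown here, compound 2, at 0.1 10^-6 cm/s, stands within the scatter of compound 1, the only other measured compound, and the two cannot be ranked. Compound 3 `Cc1oc(-c2ccccc2Cl)nc1C(=O)N[C@H]1CN(S(=O)(=O)c2ccccc2)C[C@@H]1C(=O)N[C@H]1CCCNC1` differs from compound 2 in one place: 2-chlorophenyl in place of 4-(trifluoromethyl)phenyl on an aromatic carbon. The exchanged group sits on an aromatic carbon of a five-membered aromatic ring with 1 nitrogen and 1 oxygen.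

Among the measured compounds shown here, only one measured step bears on this change: a 1.4-fold lower number from compound 1 to compound 2 (0.15 log units; within the scatter). That step put trifluoromethyl in place of chloro on an aromatic carbon, and it stayed within the scatter. For the measured compounds named here, it is a partial guide at best, since no measured compound carries 2-chlorophenyl, and two values show no trend. The expectation is therefore no step beyond the scatter in this assay, in either direction. The estimated change is a 1.3-fold higher number from compound 2 to compound 3 (0.11 log units; within the scatter), which is small. For compound 3 the expected value is 0.13 10^-6 cm/s, with an estimated range from 0.05 10^-6 cm/s to 0.4 10^-6 cm/s.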

Compound 3, apparent permeability in the Caco-2 assay: 0.13 10^-6 cm/s
Estimate against measurement, compound 3: no gap at the digits printed; the measured number falls inside the stated range.
By their numbers in the Caco-2 assay, from the lowest: compounds 2, 3 and 1 (each within the scatter of the next).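

In the Caco-2 assay, 2-chlorophenyl in place of 4-chlorophenyl gives a 1.1-fold lower number from compound 1 to compound 3 (0.03 log units; within the scatter), and 2-chlorophenyl in place of 4-(trifluoromethyl)phenyl gives a 1.3-fold higher number from compound 2 to compound 3 (0.11 log units; within the scatter), so neither exchange at this position can be read as a real change. The second exchange does register in a physicochemical assay for lipophilicity, measured as octanol-water partition, at pH 7.4 (a higher number here means a more lipophilic compound, a lower number a more polar compound), where compound 2 gives 2.3 and compound 3 gives 1.6, which makes compound 3 the more polar of the pair, yet this gap has no readable counterpart in the crossing of the cell layer: the measured distribution coefficient of compound 2, 2.3, and of compound 3, 1.6, a number 0.70 log units lower (beyond the scatter)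

Among compounds 1, 2 and 3, then, this position tolerates a different substituent on the phenyl ring, a different place for the chlorine and a measured shift in the distribution coefficient, all without a step beyond the scatter in the Caco-2 assay. The three compounds leave open whether a group of another kind on this phenyl ring, such as an amine or a carboxylic acid, would move the number beyond the scatter. They also leave open whether a shift bigger than the one seen here in the physicochemical assay, a number 0.70 log units lower from compound 2 to compound 3 (beyond the scatter), would appear in the Caco-2 assay.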